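The source may hold more compounds than are shown below. What is called first, only, known or untested is meant among the compounds shown, and "the series" means these compounds.

Compound 1 `CC(=O)OCC(CCn1cc(C#CC2CC2)c(=O)n(C(=O)c2ccccc2)c1=O)COC(C)=O` and compound 2 `CCCCCC#Cc1cn(CCC(COC(C)=O)COC(C)=O)c(=O)n(C(=O)c2ccccc2)c1=O` share one core and differ in a single place: pentyl in place of cyclopropyl on a triple-bonded carbon. In a functional assay on HeLa cells (Homo sapiens) for antiproliferative activity, read by MTT assay, with a stated time of 72 h (on this read-out lower numbers stand for stronger inhibition and higher numbers for weaker inhibition), compound 1 reaches only the limit of > 100000 nM. Compound 2 gives 53700 nM in this assay, so the change made an at least 1.8-fold lower number from compound 1 to compound 2 (0.27 log units; that floor lies within the scatter). Compound 3 `O=c1[nH]c(=O)n(CCC(CO)CO)cc1C#CC1CC1` carries the same cyclopropyl on its triple bond but sits on another core; the difference between the two cores is not broken down here. In this assay compound 3 likewise stands at the limit of > 100000 nM. Within the data shown here, two of the three values so far are limits (the limit of > 100000 nM in this assay, at which 2 of the 3 values shown sit). Compound 4 `CCCCCC#Cc1cn(CCC(CO)CO)c(=O)[nH]c1=O` applies the same change to compound 3: pentyl in place of cyclopropyl on a triple-bonded carbon. Compound 4 is expected to give about 90000 nM in this assay, between 30000 nM and 300000 nM. That expected step of an at least 1.1-fold lower number from compound 3 to compound 4 (0.04 log units; that floor lies within the scatter) rests on the earlier change having made an at least 1.8-fold lower number from compound 1 to compound 2 (0.27 log units; that floor lies within the scatter).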

Compound 4, half-maximal inhibitory concentration: 76300 nM
For compound 4 the middle estimate is 1.2-fold (0.07 log units) above the measured one, within the range that was stated.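

In this assay compound 3 gives > 100000 nM, which is a limit and not a number. On these data alone, the swap of cyclopropyl for pentyl on a triple-bonded carbon can therefore be read only as a floor, an at least 1.3-fold lower number from compound 3 to compound 4 (0.11 log units; that floor lies within the scatter), so its true size stays unknown. Set side by side, the two steps show that the change has been read on both cores, but not that it carries from one core to the other with the same size: the same change on two cores in this assay, an at least 1.8-fold lower number (0.27 log units; that floor lies within the scatter) from compound 1 to compound 2 and an at least 1.3-fold lower number (0.11 log units; that floor lies within the scatter) from compound 3 to compound 4; the limit leaves it open whether they differ.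

The compounds shown leave open how this swap would read if the starting compound had a measured number rather than a limit: the limit of > 100000 nM in this assay, at which 2 of the 4 values shown sit. They also leave open what a longer chain, or an amine or carboxylic acid at the end of the pentyl chain, would give.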